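A few compounds are considered here, and "the series" means these few. Any claim that something is new, unique, unknown or untested is made for them only; others in the source may bear on it.

Compound 3, with the structure `Nc1nc(O)c2c(n1)n(C1OC(CO)[C@@H](O)[C@H]1O)c(=O)n2Cc1ccc([N+](=O)[O-])cc1`, stands highest of the three numbers in hand: in a functional assay on the whole organism (B cells) with Mus musculus as the target (on this read-out lower numbers stand for smaller maximal responses and higher numbers for larger maximal responses), compound 3 gives 147%. Its nearest neighbour is compound 1, `CCn1c(=O)n(C2OC(CO)[C@@H](O)[C@H]2O)c2nc(N)nc(O)c21`, which in this assay gives 82%, and the furthest is compound 2, `C=CCn1c(=O)n(C2C=CC(CO)O2)c2nc(N)nc(O)c21`, which in this assay gives 45%. For the measured compounds named here, compound 2 differs from compound 3 in more than one place, so its value alone speaks and no step to it is drawn.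

Compound 4, `Nc1nc(O)c2c(n1)n(C1OC(CO)[C@@H](O)[C@H]1O)c(=O)n2CCN1CCCCC1`, is the unmeasured compound. It differs from compound 3 by (piperidin-1-yl)methyl in place of 4-nitrophenyl on a saturated chain carbon bound to an aromatic nitrogen.

Going by the values given here, the only measured step at this place is a number 65 percentage points higher from compound 1 to compound 3 (beyond the scatter), where the 4-nitrophenyl entered in place of methyl. That step shows that the group on this saturated chain carbon bound to an aromatic nitrogen can move the maximal response by a large amount. Whether (piperidin-1-yl)methyl behaves more like 4-nitrophenyl or more like methyl cannot be read from these three compounds, so the direction of the step in this assay is uncertain and a sizeable move in either direction remains possible.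

On that basis compound 4 is expected to give 100% in this assay, within a wide range from 55% to 145%. This estimate means a step of a number 47 percentage points lower from compound 3 to compound 4 (beyond the scatter), expected to fall back toward the level of compound 1.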

Compound 4, largest response reached (reported as maximal response), in percent of the reference or control that the assay uses: 0%
Estimate against measurement, compound 4: 100 percentage points above; the measured number lies below the stated range.
By their numbers in this assay, from the lowest: compound 4; then compound 2; then compound 1; then compound 3.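

The change from 4-nitrobenzyl to 2-(piperidin-1-yl)ethyl gave a number 147 percentage points lower from compound 3 to compound 4 (beyond the scatter) in this assay, and adding piperidin-1-yl on a saturated chain carbon, two bonds along the chain from an aromatic nitrogen, gave a number 82 percentage points lower from compound 1 to compound 4 (beyond the scatter) on the same read-out. The earlier compounds had shown only that a change at this place could raise the maximal response, whereas these steps show that it can also take the response down to nothing, so that compound 1 lies well inside the span set by compound 3 and compound 4. Nothing available accounts for this fall.

Compound 4 cannot separate the arrival of the piperidin-1-yl ring from the loss of the 4-nitrophenyl ring, and a plain benzyl, a 2-phenylethyl or a 2-cyclohexylethyl group at the same place would help to tell these apart. Going by these compounds, it also remains open whether the response is lost with any amine on this chain, as a 2-(morpholin-4-yl)ethyl or 2-(dimethylamino)ethyl group would show, or whether the result is particular to piperidin-1-yl.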